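From Chloro to Nitrooxy on Compound 2

The compounds below may be only part of what the source reports. "The series", "measured", "known", "first", "only" and "open" are said of these compounds alone.

In a functional assay on MDA-MB-231 cells (Homo sapiens) for antiproliferative activity, read by CCK-8 assay and cell counting, with a stated time of 72 h (on this read-out higher numbers stand for weaker inhibition and lower numbers for stronger inhibition), compound 2 `O=C(Nc1ccccc1)c1ccc(CCl)cc1` gives 800 nM, level with compound 1 `O=C(Nc1ccccc1OC(=O)c1ccc(CCl)cc1)c1ccc(CCl)cc1` at 800 nM, and the two values lie within the scatter of each other. Compound 3 `O=C(Nc1ccccc1)c1ccc(CO[N+](=O)[O-])cc1` keeps the shared core of compound 2 and differs from it in one place: nitrooxy in place of chloro on a saturated chain carbon bound to an aromatic carbon. In words, nitrooxy stands in place of chloro on a saturated chain carbon bound to an aromatic carbon. Going by the values given here, both measured compounds carry chloromethyl, compound 3 does not, and no measured pair shows this exchange, so the guidance is thin. In this assay, a moderate weakening of inhibition, a little beyond the scatter, is expected. The estimated step is a 2.5-fold higher number from compound 2 to compound 3 (0.40 log units; beyond the scatter). Compound 3 is expected to give about 2000 nM, with an estimated range of 400 nM to 10000 nM.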

Compound 3, half-maximal inhibitory concentration: 800 nM
Beside the measured number, compound 3's estimate is 2.5-fold (0.40 log units) above it; the range from low to high includes it.
By their numbers in this assay, from the lowest: compounds 1, 2 and 3 (each within the scatter of the next).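

In this assay, nitrooxy in place of chloro on a saturated chain carbon bound to an aromatic carbon gives no change at the digits printed from compound 2 to compound 3 (within the scatter). Going by these compounds alone, the earlier compounds both carried chloromethyl and so said nothing about this exchange; this pair is the first to show that the position accepts (nitrooxy)methyl, with four heavy atoms and three hydrogen-bond acceptors entering where one chlorine leaves, and the read-out stays within the scatter. The data shown offer no explanation for this flat result.

As far as these compounds go, whether the same position would read alike with an amine, a carboxylic acid or a longer chain on that carbon remains open. Also open, from the compounds shown here alone, is whether the level reading of compound 2 and compound 3 would hold in any other cell line.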